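This account rests on a few compounds, and the source may have more. Where it says the series, first, only, none or still open, it means among the compounds named here.

Compounds measured:
Compound 1, `Nc1nc(N)c(-c2ccc(NCc3ccc([N+](=O)[O-])cc3)cc2)c(COCc2ccccc2)n1`, 0.2 nM
Compound 2, `Nc1nc(N)c(-c2ccc(NCc3ccnc(Cl)c3)cc2)c(COCc2ccccc2)n1`, 1.5 nM
Compound 3, `COc1ccc(CNc2ccc(-c3c(N)nc(N)nc3COCc3ccccc3)cc2)cc1`, 7.7 nM

In an in vitro assay on CHOK cells for displacement of a labelled ligand from growth hormone secretagogue receptor type 1 (Homo sapiens) (on this read-out higher numbers stand for weaker inhibition and lower numbers for stronger inhibition), compound 3 gives the highest number of the three, and both of its distances to the others lie beyond the scatter: a 5.1-fold higher number from compound 2 to compound 3 (0.71 log units; beyond the scatter) and a 39-fold higher number from compound 1 to compound 3 (1.59 log units; beyond the scatter). It is therefore the weakest binder shown.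

Compound 4, `N#Cc1ccc(COc2ccc(-c3c(N)nc(N)nc3COCc3ccccc3)cc2)cc1`, has not been measured. It differs from compound 3 in one place: (4-cyanobenzyl)oxy in place of (4-methoxybenzyl)amino on an aromatic carbon. Two things change at once: the group on the outer ring and the atom that links the chain to the core.

The measured steps speak only to the first of these. Swapping nitro for methoxy on the outer ring gave a 39-fold higher number from compound 1 to compound 3 (1.59 log units; beyond the scatter), a large loss, and exchanging the whole outer ring gave a 7.5-fold higher number from compound 1 to compound 2 (0.88 log units; beyond the scatter) and a 5.1-fold higher number from compound 2 to compound 3 (0.71 log units; beyond the scatter). The group on that ring clearly matters. Nothing measured here tests an oxygen linker in place of the nitrogen, so that part is uncertain.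

Since compound 3 sits at the weak end, a gain toward compound 1 is expected, tempered by the untested linker: a 3.9-fold lower number from compound 3 to compound 4 (0.59 log units; beyond the scatter). Compound 4 is estimated at 2 nM, within 0.4 nM to 15 nM.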

Compound 4, half-maximal inhibitory concentration: 83 nM
Compound 4: middle estimate off by 42-fold (1.62 log units), on the low side, and the stated range ends below it.
By their numbers in this assay, from the lowest: compound 1; then compound 2; then compound 3; then compound 4.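

In this assay, putting (4-cyanobenzyl)oxy in place of (4-methoxybenzyl)amino on this aromatic carbon gave an 11-fold higher number from compound 3 to compound 4 (1.03 log units; beyond the scatter), and the distance to the stronger binders is wider still, with a 55-fold higher number from compound 2 to compound 4 (1.74 log units; beyond the scatter) and a 420-fold higher number from compound 1 to compound 4 (2.62 log units; beyond the scatter), so compound 4 is the weakest binder of the four. Among the compounds shown here, the earlier compounds all kept the amino link and varied only the outer ring, so this is the first sign that the position tolerates a combined change of link and ring group poorly, even though both groups count 10 heavy atoms; what does differ in the counts is that the group leaving has 1 hydrogen-bond donor and the group entering has 0 hydrogen-bond donors. Nothing available here explains the rise in the number.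

The link and the ring group change together in this step, so the compounds shown cannot divide the loss between them; (4-cyanobenzyl)amino and (4-methoxybenzyl)oxy would each change only one of the two. Also open, going by these compounds, is how other links would behave at this position, such as a sulfur atom, an amide or a longer chain.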